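The compounds below may be only part of what the source reports. "The series", "measured", "known", "first", "only" and "open" are said of these compounds alone.

Working notes on the hydroxamic acid series

Three members of the series have been measured, and they differ from one another only in the group carried on an aromatic carbon. Compound 1 `O=C(CCC1=CCN(CCCc2ccc(Cl)cc2)C1=O)NO` gives 2200 nM in a functional assay on NUGC-3 cells (Homo sapiens) for inhibition, read by sulforhodamine B assay; on this read-out lower numbers stand for stronger inhibition of growth and higher numbers for weaker inhibition of growth. Compound 2 `CC(C)(C)c1ccc(CCCN2CC=C(CCC(=O)NO)C2=O)cc1` gives 2200 nM in this assay, and compound 3 `Cc1ccc(CCCN2CC=C(CCC(=O)NO)C2=O)cc1` gives 2200 nM. The three steps among them are all flat: no change at the digits printed from compound 1 to compound 2 (within the scatter), no change at the digits printed from compound 1 to compound 3 (within the scatter), and no change at the digits printed from compound 2 to compound 3 (within the scatter). Among the measured compounds shown here, compound 3 therefore stands level with compounds 1 and 2 on the numbers so far; nothing separates it from either of them.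

Compound 4 `CC(C)c1ccc(CCCN2CC=C(CCC(=O)NO)C2=O)cc1` differs from compound 3 in one place: isopropyl in place of methyl on an aromatic carbon. The measured step that bears most directly on this change is no change at the digits printed from compound 2 to compound 3 (within the scatter), where a smaller alkyl group replaced a larger one on the same aromatic carbon without any effect beyond the scatter. The steps from compound 1, no change at the digits printed from compound 1 to compound 2 (within the scatter) and no change at the digits printed from compound 1 to compound 3 (within the scatter), point the same way: neither size nor kind of group at this position has so far moved the read-out.

Accordingly compound 4 is expected to show no step beyond the scatter, no change at the digits printed from compound 3 to compound 4 (within the scatter), in this assay. The estimate for compound 4 is 2200 nM, with a range from 1100 nM to 4400 nM.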

Compound 4, concentration for 50% growth inhibition: 2200 nM
Compound 4: middle estimate and measured number agree at the digits printed, within the range that was stated.
By their numbers in this assay, from the lowest: compounds 1, 2, 3 and 4 (each within the scatter of the next).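

The aromatic carbon para to a large group now also carries isopropyl, and in this assay the step is no change at the digits printed from compound 3 to compound 4 (within the scatter), so 3 heavy atoms in place of 1 heavy atom leave the read-out unmoved. Compared with the other two groups, the result is no change at the digits printed from compound 2 to compound 4 (within the scatter) and no change at the digits printed from compound 1 to compound 4 (within the scatter), so methyl, isopropyl, tert-butyl and chloro all read alike at this position, and no compound among the four goes against that. No supporting measurement bears on why this position is so flat.

On these data alone, all four compounds carry a carbon- or chlorine-based group at this one aromatic carbon, so it remains open whether a carboxylic acid, an amine or plain hydrogen there would also leave growth inhibition unchanged. Also open is whether the same flatness would hold with a longer chain between the aromatic ring and the shared core, or with a carboxylic acid in place of the hydroxamic acid, as every compound shown keeps both of those parts unchanged.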